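A few compounds are considered here, and "the series" means these few. Any claim that something is new, unique, unknown or untested is made for them only; others in the source may bear on it.

Measured so far in a functional assay on the whole organism (strain Swiss albino) with Mus musculus as the target, in the maximal electroshock model, with a stated time of 0.5 h; a lower number here means that less compound is needed, a higher number that more compound is needed for the effect:
compound 1 `O=C(N/N=C/c1ccc(Cl)cc1Cl)Nc1cccc2ccccc12`: 100 mg/kg
compound 2 `COc1cc(/C=N/NC(=O)Nc2cccc3ccccc23)cc(OC)c1OC`: 100 mg/kg
compound 3 `O=C(N/N=C/c1ccc(O)cc1)Nc1cccc2ccccc12`: 100 mg/kg

Compound 2 stands level with compound 1 and compound 3; the three values lie within the scatter of one another, so no order among them can be read. Among the measured compounds shown here, the only step between compounds differing in one place, no change at the digits printed from compound 1 to compound 3 (within the scatter), shows that exchanging the whole aryl group on the carbon with a double bond to nitrogen left the minimum effective dose unmoved. Compound 4 `COc1ccc(/C=N/NC(=O)Nc2cccc3ccccc23)cc1OC` differs from compound 2 by hydrogen in place of methoxy on an aromatic carbon. For the measured compounds named here, no measured step removes a methoxy group, so that one step bears on it only indirectly, as a sign that the measured set is so far flat. For compound 4 the expected step is no change at the digits printed from compound 2 to compound 4 (within the scatter), none beyond the scatter. Compound 4 is therefore estimated at 100 mg/kg, with a range from 50 mg/kg to 200 mg/kg.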

Compound 4, minimum effective dose: 100 mg/kg
Compound 4: the middle estimate sits on the measured number at the digits printed; the measured number falls inside the stated range.
By their numbers in this assay, from the lowest: compounds 1, 2, 3 and 4 (each within the scatter of the next).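

In this assay the exchange of methoxy for hydrogen on this aromatic carbon gives no change at the digits printed from compound 2 to compound 4 (within the scatter) and so adds a single-group change at one position to the earlier exchange of the whole aryl group. This methoxy group, ortho to a methoxy group, is therefore not needed to keep the minimum effective dose at this level in this pair. Nothing available accounts for the flat result.

Still open, going by these compounds, is whether an amine or a carboxylic acid on this carbon would move the dose. Also open, on these data alone, is whether any change to the shared core would.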